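The compounds below may be only part of what the source reports. "The series", "measured", "known", "first", "only" and "open" are said of these compounds alone.

Compounds measured in a functional assay on PC-9 cells (Homo sapiens) for inhibition, read by MTT assay, with a stated time of 48 h, tested at 10 uM; on this read-out lower numbers stand for less inhibition and higher numbers for more inhibition at the one concentration tested (going by the name of the read-out):

Compound 1 `COc1ccc(C(F)(F)F)cc1Nc1cc(NC(=O)Nc2c(Cl)cccc2Cl)ncn1` gives 89%.
Compound 2 `COc1cc(Nc2cc(NC(=O)Nc3c(Cl)cccc3Cl)ncn2)cc(OC)c1` gives 90%.
Compound 3 `COc1cc(Nc2cc(NC(=O)Nc3c(Cl)cccc3Cl)ncn2)cc(C(F)(F)F)c1` gives 88.5%.

All three measured compounds share the urea-linked core and differ only in the substituents on the aniline ring. Compound 3 and compound 2 differ in one place, (methoxy in place of trifluoromethyl on an aromatic carbon), and this change made a number 1.5 percentage points higher from compound 3 to compound 2 (within the scatter). Compound 1 and compound 3 have the same atoms joined differently, and the difference between the two cores is not broken down here; their two values lie within the scatter of each other, as do the values of compound 1 and compound 2.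

Compound 4 `COc1ccc(OC)c(Nc2cc(NC(=O)Nc3c(Cl)cccc3Cl)ncn2)c1` has not yet been measured in this assay. It differs from compound 1 by methoxy in place of trifluoromethyl on an aromatic carbon. Among the measured compounds shown here, this is the same kind of change as the one from compound 3 to compound 2, but not the same: in compound 1 the site is para to a methoxy group, whereas in compound 3 it is meta to a methoxy group. Since that earlier change made a number 1.5 percentage points higher from compound 3 to compound 2 (within the scatter), and since every measured compound sits in the same high range, compound 4 is expected to give a step of no change at the digits printed from compound 1 to compound 4 (within the scatter) from compound 1, an estimate resting on the step from compound 3 to compound 2. Compound 4 is therefore estimated at 89%, with a likely range from 80% to 95%.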

Compound 4, a percentage reported as inhibition, at one concentration (the size of the read-out at that concentration, not a potency): 95%
The estimate for compound 4 lay 6 percentage points below the measured number, within the range that was stated.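

In this assay, methoxy in place of trifluoromethyl on an aromatic carbon gave a number 6 percentage points higher from compound 1 to compound 4 (within the scatter). Set beside the earlier case of the same change, on the other core, the two steps cannot be told apart: the same change on two cores in this assay, a number 1.5 percentage points higher (within the scatter) from compound 3 to compound 2 and a number 6 percentage points higher (within the scatter) from compound 1 to compound 4, 4.5 percentage points apart, within the scatter of two such steps. Among the compounds shown here, this shows that on these two cores the change left the read-out within the scatter, but it does not show that methoxy raises the read-out on either core, and with only two pairs, each with the site placed differently, it gives no rule for carrying the change to a further core; a reading at one concentration also says nothing about potency, so differences in potency between these compounds could remain unseen.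

The compounds shown leave open whether an amine, a carboxylic acid or a longer alkoxy chain in the place of the methoxy or trifluoromethyl group would keep the read-out in the same range. They also leave open what happens when the two chlorine atoms of the shared core give way to hydrogen or to methyl groups, since every compound here carries both chlorines.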